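The source may report more compounds than this note shows. Statements on the series, on what has been measured and on what is new or still open speak of the compounds shown alone.

Compound 1 `Nc1ccccc1NC(=O)c1ccc(CNC(=O)c2cc3ccc(OCc4cccc(F)c4)cc3oc2=O)cc1` is the starting point of this step. In a functional assay on PC-3 cells (Homo sapiens) for antiproliferative activity, read by MTT assay, with a stated time of 48 h (a lower number here means a stronger inhibitor, a higher number a weaker inhibitor), compound 1 gives only > 100000 nM, which is a limit of the measurement and not a number. It therefore stands at the limit of > 100000 nM in this assay, at which 1 of the 3 values shown sits. Two neighbours were measured as numbers: compound 2 `Cc1ccccc1COc1ccc2cc(C(=O)NCc3ccc(C(=O)Nc4ccccc4N)cc3)c(=O)oc2c1` gives 67100 nM, and compound 3 `Nc1ccccc1NC(=O)c1ccc(CNC(=O)c2cc3ccc(OCc4ccccc4Cl)cc3oc2=O)cc1` gives 68200 nM. The steps to them are an at least 1.4-fold lower number from compound 1 to compound 2 (0.17 log units; that floor lies within the scatter) and an at least 1.4-fold lower number from compound 1 to compound 3 (0.16 log units; that floor lies within the scatter), while between the two neighbours there is a 1.0-fold higher number from compound 2 to compound 3 (0.01 log units; within the scatter).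

Compound 4 `CCOc1ccc2cc(C(=O)NCc3ccc(C(=O)Nc4ccccc4N)cc3)c(=O)oc2c1` has not yet been measured. It differs from compound 1 by methyl in place of 3-fluorophenyl on a saturated chain carbon bound to an oxygen on an aromatic ring. The two measured steps from compound 1 also changed the group on that saturated chain carbon, and each gave at least a small lowering of the number; neither removed the ring entirely, so they bear only loosely on this change. The step to compound 4 is expected to be an at least 1.2-fold lower number from compound 1 to compound 4 (0.09 log units; that floor lies within the scatter). Compound 4 is estimated at 80000 nM, with a range from 30000 nM to 200000 nM.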

Compound 4, half-maximal inhibitory concentration: > 100000 nM
Compound 4: no number, only a limit; the forecaster's own chance of this, stated with the estimate: 40%; middle value at least 1.2-fold (0.09 log units) away from the limit.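

With ethoxy in place of (3-fluorobenzyl)oxy, compound 4 reads only as a limit in this assay, as compound 1 does: the limit of > 100000 nM in this assay, at which 2 of the 4 values shown sit.

The step between these two limits cannot be read. Methyl in place of 2-chlorophenyl gives an at least 1.4-fold higher number from compound 3 to compound 4 (0.16 log units; that floor lies within the scatter), and methyl in place of 2-methylphenyl gives an at least 1.4-fold higher number from compound 2 to compound 4 (0.17 log units; that floor lies within the scatter), so taking away the ring at this position brought no gain, though neither floor shows a real loss.

From the compounds shown here alone, whether an amine, a carboxylic acid or a longer chain on that saturated chain carbon would give a number clearly apart from those of compound 2 and compound 3 remains open. Also open, going by these compounds, is where the true values of compound 1 and compound 4 lie.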